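This account rests on a few compounds, and the source may have more. Where it says the series, first, only, none or still open, it means among the compounds named here.

The compounds share one core, carried by compound 1 `COc1ccc(C(=O)/N=C2\NC3(CCCCO3)CCS2)cc1`, compound 2 `O=C(/N=C1\NC2(CCCCO2)CCS1)c1ccc(F)cc1` and compound 3 `O=C(/N=C1\NC2(CCCCO2)CCS1)c1ccc(Br)cc1`, which differ only in the group on the aromatic ring. In a functional assay on the whole organism (strain CF-1) with Mus musculus as the target, in the writhing test, with a stated time of 15 min (on this read-out higher numbers stand for an effect only at larger amounts of compound and lower numbers for an effect already at smaller amounts), compound 1 gives 62 mg/kg. In this assay compound 2 gives 8.8 mg/kg; 28 mg/kg; 49 mg/kg (3 entries), a spread of entries recorded in the several entries of compound 2 in this assay, 8.8 mg/kg; 28 mg/kg; 49 mg/kg (3 entries). For compound 3 this assay reports only a limit, > 200 mg/kg, and no single number, as noted in the limit of > 200 mg/kg in this assay, at which 1 of the 3 values shown sits. For the measured compounds named here, compound 3 therefore stands apart from the two compounds with definite numbers, and the one comparable step, an at least 3.2-fold higher number from compound 1 to compound 3 (0.50 log units; beyond the scatter), runs toward the higher number. Compound 4 `O=C(/N=C1\NC2(CCCCO2)CCS1)c1ccc(Cl)cc1` differs from compound 3 by chloro in place of bromo on an aromatic carbon. Going by the values given here, no measured step exchanges one halogen for another, so the expectation rests on compound 2, which carries fluoro, and on compound 3. In this assay compound 2 gives 8.8 mg/kg; 28 mg/kg; 49 mg/kg (3 entries). For compound 3 only a limit is available in this assay. Chloro sits between fluoro and bromo, so compound 4 is expected to fall between those, with a step of an at least 2.0-fold lower number from compound 3 to compound 4 (0.30 log units; that floor lies within the scatter) expected from the limit. Compound 4 is estimated at 100 mg/kg, with a range from 30 mg/kg to 300 mg/kg expected.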

Compound 4, dose for half-maximal effect: 1.1 mg/kg
Compound 4: middle estimate off by 91-fold (1.96 log units), on the high side, outside the stated range (below it).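

In this assay, for the compounds shown here, the aromatic carbon para to a large group proves far more sensitive to a single atom than the earlier compounds showed: exchanging bromo for chloro gives an at least 180-fold lower number from compound 3 to compound 4 (2.25 log units; beyond the scatter), and exchanging methoxy for chloro gives a 56-fold lower number from compound 1 to compound 4 (1.75 log units; beyond the scatter). The halogens do not fall in the order of their sequence in the table of elements, as compound 4 with chloro, at 1.1 mg/kg, lies lower than each entry of compound 2 with fluoro, whose values are widely spread: the several entries of compound 2 in this assay, 8.8 mg/kg; 28 mg/kg; 49 mg/kg (3 entries). The figure for compound 3 is only a limit, so the first of these steps has a floor and no exact size: the limit of > 200 mg/kg in this assay, at which 1 of the 4 values shown sits.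

The compounds shown carry only methoxy, fluoro, chloro and bromo at this place, so it stays open whether a methyl group, a trifluoromethyl group or a nitrile would match chloro or fall away as bromo does. The shared core is also the same throughout, and what lies behind the sharp difference between chloro and bromo, and whether it would survive a change to that core, remains unanswered.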